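Working notes: the step from compound 2 to compound 4

This account rests on a few compounds, and the source may have more. Where it says the series, first, only, none or still open, it means among the compounds named here.

Measured in a functional assay on MCF7 cells (Homo sapiens) for cytotoxicity, read by MTT assay, with a stated time of 72 h; a lower number here means a stronger inhibitor, a higher number a weaker inhibitor:
- compound 1 `COc1cccc(/C=C2\CCC/C(=C\c3ccc(Cl)cc3)C2=O)c1OC`: 10300 nM
- compound 2 `COc1cccc(/C=C2\CCC/C(=C\c3cccc(Br)c3)C2=O)c1OC`: 11700 nM
- compound 3 `COc1cccc(/C=C2\CCC/C(=C\c3ccc(Br)cc3)C2=O)c1OC`: 13800 nM

Compound 2, at 11700 nM, lies within the scatter of the other two compounds, so the three values cannot be ranked. Next in the series is compound 4 `COc1ccc(/C=C2\CCC/C(=C\c3cccc(OC)c3OC)C2=O)cc1`. The change is 4-methoxyphenyl in place of 3-bromophenyl on a double-bonded chain carbon bound to a double-bonded ring carbon.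

Going by the values given here, three measured steps bear on this place. The chloro-to-bromo swap gave a 1.3-fold higher number from compound 1 to compound 3 (0.13 log units; within the scatter), the 3-bromophenyl to 4-bromophenyl change gave a 1.2-fold higher number from compound 2 to compound 3 (0.07 log units; within the scatter), and the remaining pair gave a 1.1-fold higher number from compound 1 to compound 2 (0.06 log units; within the scatter). All three stay within the scatter, but none introduces a methoxy group at this place, so the guidance is indirect and the range is kept wide. No step beyond the scatter is expected in this assay, and no direction is favoured. The estimated step is a 1.1-fold lower number from compound 2 to compound 4 (0.03 log units; within the scatter). For compound 4 the expected value is 11000 nM, with an estimated range of 4500 nM to 25000 nM.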

Compound 4, half-maximal inhibitory concentration: 18600 nM
Beside the measured number, compound 4's estimate is 1.7-fold (0.23 log units) below it, within the range that was stated.
By their numbers in this assay, from the lowest: compounds 1, 2, 3 and 4 (each within the scatter of the next).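

In this assay, going by these compounds alone, 4-methoxyphenyl brings the first oxygen-bearing group to this place, on a double-bonded chain carbon bound to a double-bonded ring carbon, and the result stays within the scatter (a 1.6-fold higher number from compound 2 to compound 4 (0.20 log units; within the scatter)). Methoxy in place of bromo (a 1.3-fold higher number from compound 3 to compound 4 (0.13 log units; within the scatter)) and methoxy in place of chloro (a 1.8-fold higher number from compound 1 to compound 4 (0.26 log units; within the scatter)) also stay within the scatter, so a group with a hydrogen-bond acceptor joins the halogen-bearing groups without any step beyond the scatter among compounds 1 to 4. No supporting evidence accompanies these steps to explain the result.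

The compounds shown leave open whether any group at this place can produce a step beyond the scatter. An amine or a carboxylic acid on the phenyl ring would test this with a different kind of group.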